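Methyl in Place of Methoxy on the Aryl Ether of Compound 2

The source may report more compounds than this note shows. Statements on the series, on what has been measured and on what is new or still open speak of the compounds shown alone.

Compound 1, `COc1ccc(OC[C@@H]2CCc3cc([C@H]4CC[C@](N)(CO)C4)ccc3C2)cc1C(C)(C)C`: 53%
Compound 2, `COc1ccc(OC[C@@H]2CCc3cc([C@H]4CC[C@](N)(CO)C4)ccc3C2)cc1`: 47%

In a functional assay on the whole organism (strain Lewis) with Rattus norvegicus as the target, with a stated time of 24 h, at a dose of 2 mg/kg by the oral route (a lower number here means less inhibition, a higher number more inhibition at the dose given (going by the name of the read-out)), compound 1 gives 53%, while compound 2 gives 47%. Compound 2 therefore stands alongside compound 1 rather than apart from it, since the step of a number 6 percentage points lower from compound 1 to compound 2 (within the scatter) lies within the scatter; the two numbers cannot be told apart. Compound 3, `Cc1ccc(OC[C@@H]2CCc3cc([C@H]4CC[C@](N)(CO)C4)ccc3C2)cc1`, differs from compound 2 in one place: methyl in place of methoxy on an aromatic carbon. Going by the values given here, only one measured step is at hand, and it concerns a different group on the same ring, hydrogen in place of tert-butyl, with the change a number 6 percentage points lower from compound 1 to compound 2 (within the scatter) staying within the scatter. Nothing measured bears directly on the exchange of methoxy for methyl, so the expectation for compound 3 in this assay is a step of a number 2 percentage points lower from compound 2 to compound 3 (within the scatter), that is, none beyond the scatter. Compound 3 is thus estimated at 45%, within 25% to 65%.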

Compound 3, a percentage reported as inhibition, in the whole organism at one dose (the size of the read-out at that dose, not a potency): 20%
Estimate against measurement, compound 3: 25 percentage points above; the whole stated range lies above it.
By their numbers in this assay, from the lowest: compound 3; then compounds 2 and 1 (each within the scatter of the next).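

In this assay, going by these compounds alone, the exchange of methoxy for methyl gives a number 27 percentage points lower from compound 2 to compound 3 (beyond the scatter), whereas the only earlier step, a number 6 percentage points lower from compound 1 to compound 2 (within the scatter), stayed within the scatter. The read-out at this dose therefore does respond to the group on this aromatic carbon, para to a large group: methoxy and methyl are not interchangeable here, although the change removes only one heavy atom and one hydrogen-bond acceptor. The data at hand offer no measurement that accounts for the size of this step.

The compounds shown leave open whether the oxygen atom of the methoxy group matters in itself or whether other groups on this carbon would give numbers like that of methyl. Ethoxy, hydroxyl or an amine at this place, none of them among these compounds, would bear on that question.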